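The source may hold more compounds than are shown below. What is called first, only, known or untested is meant among the compounds shown, and "the series" means these compounds.

Three compounds built on one shared core have been examined in an ADME assay on HepG2 cells (Homo sapiens) for cytotoxicity, read by MTT assay, with a stated time of 48 h; a lower number here means that less compound is tolerated, a higher number that more compound is tolerated. Compound 1 `CC(=O)OC[C@H]1O[C@H](OC[C@@H](Cn2cc(CN(c3nc(-c4ccc(Cl)cc4)no3)C3CCCCC3)nn2)OC(C)=O)C=C[C@@H]1OC(C)=O` gives 46.9 ug/mL, compound 2 `CC(=O)OC[C@H]1O[C@H](OC[C@@H](Cn2cc(CN(c3nc(-c4ccc(Br)cc4)no3)C3CCCCC3)nn2)OC(C)=O)C=C[C@@H]1OC(C)=O` gives 47.6 ug/mL, and compound 3 `CC(=O)OC[C@H]1O[C@H](OC[C@@H](Cn2cc(CN(c3nc(-c4ccccc4)no3)C3CCCCC3)nn2)OC(C)=O)C=C[C@@H]1OC(C)=O` gives 19.9 ug/mL, the lowest of the three numbers. The structural difference between compound 3 and compound 4 `COc1ccc(-c2noc(N(Cc3cn(C[C@H](CO[C@@H]4C=C[C@H](OC(C)=O)[C@@H](COC(C)=O)O4)OC(C)=O)nn3)C3CCCCC3)n2)cc1` is methoxy in place of hydrogen on an aromatic carbon. For the measured compounds named here, two measured steps bear on this change, since they alter the same aromatic carbon: a 2.4-fold lower number from compound 1 to compound 3 (0.37 log units; beyond the scatter) and a 2.4-fold lower number from compound 2 to compound 3 (0.38 log units; beyond the scatter). In both, replacing chloro or bromo with hydrogen on that aromatic carbon lowered the number, so moving the other way, from hydrogen to a substituent, points toward a higher number. Going by the values given here, a methoxy group is neither chloro nor bromo, and no measured step shows what a methoxy group does here, so the expectation is held loosely. For compound 4 the expected step in this assay is a 1.6-fold higher number from compound 3 to compound 4 (0.21 log units; within the scatter), giving an estimated value of 32 ug/mL, with a range from 15 ug/mL to 65 ug/mL.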

Compound 4, half-maximal cytotoxic concentration: 141 ug/mL
Estimate against measurement, compound 4: 4.4-fold (0.64 log units) below, outside the stated range (above it).
By their numbers in this assay, from the lowest: compound 3; then compounds 1 and 2 (each within the scatter of the next); then compound 4.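

In this assay the methoxy group sets this aromatic carbon apart more clearly than the halogens did, with a 7.1-fold higher number from compound 3 to compound 4 (0.85 log units; beyond the scatter), alongside a 3.0-fold higher number from compound 1 to compound 4 (0.48 log units; beyond the scatter) and a 3.0-fold higher number from compound 2 to compound 4 (0.47 log units; beyond the scatter). The earlier compounds shown here showed only that chloro and bromo gave numbers within the scatter of each other, both higher than with hydrogen; now the groups that replace hydrogen at this carbon also differ from one another. Nothing measured here gives a reason for the methoxy result.

From the compounds shown here alone, it remains open whether the oxygen atom or the whole methoxy group matters, something a hydroxy, methyl or ethoxy group at this carbon could help to separate. Going by these compounds, it is also open whether the step from hydrogen to methoxy would stay this large if another part of the shared core were changed.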